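Ethoxy in place of fluoro: notes toward compound 3

The compounds below may be only part of what the source reports. "The series", "measured", "known", "first", "only" and "open" are said of these compounds alone.

Measured so far in a functional assay on MCF7 cells (Homo sapiens) for inhibition, with a stated time of 48 h (on this read-out lower numbers stand for stronger inhibition and higher numbers for weaker inhibition), for this series:
- compound 1 (`COc1cc(Sc2c[nH]c3ccc(F)cc23)cc(OC)c1OC`) gives 160 nM in this read-out
- compound 2 (`COc1ccc2[nH]c(C)c(Sc3cc(OC)c(OC)c(OC)c3)c2c1`) gives 18 nM in this read-out

Compound 1 holds the higher of the two numbers. Within the data shown here, compound 2 at 18 nM is the only neighbouring value, and it lies lower by a gap beyond the scatter. Compound 1 therefore stands at the weak end of this very small set.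

Compound 3 (`CCOc1ccc2[nH]cc(Sc3cc(OC)c(OC)c(OC)c3)c2c1`) has not been measured yet. Relative to the core of compound 1 it carries ethoxy in place of fluoro on an aromatic carbon, a change counted as ethoxy in place of fluoro on an aromatic carbon in full. Among the measured compounds shown here, no measured pair isolates this change, so its size in this assay cannot be read directly and remains a judgement. A moderate fall in the number is expected, probably beyond the scatter. For the measured compounds named here, the only support is that compound 2 at 18 nM shows much lower numbers occur. The expected change is a 2.7-fold lower number from compound 1 to compound 3 (0.43 log units; beyond the scatter) on this basis, with wide uncertainty. For compound 3 the estimate is 60 nM as the expected value, with an estimated range from 15 nM to 240 nM as the likely span.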

Compound 3, half-maximal inhibitory concentration: 16 nM
Beside the measured number, compound 3's estimate is 3.8-fold (0.57 log units) above it, and the stated range covers the measured number.
By their numbers in this assay, from the lowest: compounds 3 and 2 (each within the scatter of the next); then compound 1.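

In this assay, among these compounds, ethoxy in place of fluoro on an aromatic carbon gives a 10-fold lower number from compound 1 to compound 3 (1.00 log units; beyond the scatter), the only single-place step in this set, so this position now has a directly read effect on the number. The step is beyond the scatter and shows that fluoro is not needed here for a low number: compound 3, with ethoxy, gives 16 nM. No measurement in hand bears on what lies behind the step, which stands as an observation on this one pair.

A single pair leaves open how the number responds to other groups at this place, such as a longer chain like propoxy, a hydroxyl or an amine, and whether the ether oxygen or the two-carbon chain of ethoxy carries the step. Among the compounds shown here, the other differences in compound 2, including its methyl group, cannot be read, since no measured pair isolates any of them.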